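A few compounds are considered here, and "the series" means these few. Any claim that something is new, unique, unknown or untested is made for them only; others in the source may bear on it.

Measured compounds:
compound 1 `Cc1ccc(C2CN(S(=O)(=O)c3ccccc3)C(=O)N2)cc1`, > 316000 nM;
compound 2 `Cc1ccc(C2CN(S(=O)(=O)c3ccc(Cl)cc3)C(=O)N2)cc1`, 158000 nM;
compound 3 `O=C1NCC(c2ccc(Cl)cc2)N1S(=O)(=O)c1ccc2c(c1)CCC2`, > 265000 nM.

In a functional assay on A549 cells (Homo sapiens) for cytotoxicity (a lower number here means a stronger inhibitor, a higher number a weaker inhibitor), compound 2 gives 158000 nM. For compound 1 the value > 316000 nM is only a limit of this assay. For compound 3 the value > 265000 nM is likewise only a limit. For the measured compounds named here, the one counted step is an at least 2.0-fold higher number from compound 2 to compound 1 (0.30 log units; that floor lies within the scatter), made by hydrogen in place of chloro on an aromatic carbon. How the core of compound 3 differs from the core of compound 2 is not broken down here.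

Compound 4 `O=C1NCC(c2ccccc2)N1S(=O)(=O)c1ccc2c(c1)CCC2` has not been measured. It arises from compound 3 by hydrogen in place of chloro on an aromatic carbon, the same change as from compound 2 to compound 1. Since compound 3 already sits at the limit of > 265000 nM in this assay, at which 1 of the 3 values shown sits, and the earlier step of an at least 2.0-fold higher number from compound 2 to compound 1 (0.30 log units; that floor lies within the scatter) went toward a weaker inhibitor, the step that the limit leaves unreadable from compound 3 to compound 4 is expected to move the same way, most likely ending at a limit. The estimate for compound 4 in this assay is 600000 nM.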

Compound 4, half-maximal inhibitory concentration: 58500 nM
Estimate against measurement, compound 4: 10-fold (1.01 log units) above; the measured number lies below the stated range.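

In this assay, going from 4-chlorophenyl to phenyl on the core of compound 3 gives an at least 4.5-fold lower number from compound 3 to compound 4 (0.65 log units; beyond the scatter). Set beside the same change on the other core, the direction does not carry over: the same change on two cores in this assay, an at least 2.0-fold higher number (0.30 log units; that floor lies within the scatter) from compound 2 to compound 1 and an at least 4.5-fold lower number (0.65 log units; beyond the scatter) from compound 3 to compound 4, at least 9.0-fold (0.95 log units) apart, beyond the scatter of two such steps. Each step has one end at a limit, so only a floor for its size is known, and the two cores show that the outcome of this change differs between them, not what causes the difference.

Open, as far as these compounds go, is how the core of compound 3 would respond to an amine or a carboxylic acid in place of chloro. Also open, from the compounds shown here alone, is which direction the change from chloro to hydrogen would take on a third core.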